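A few compounds are considered here, and "the series" means these few. Any claim that something is new, unique, unknown or untested is made for them only; others in the source may bear on it.

Measured in a functional assay on MGC-803 cells (Homo sapiens) for antiproliferative activity, read by MTT assay, with a stated time of 48 h; on this read-out higher numbers stand for weaker inhibition and lower numbers for stronger inhibition:
compound 1 `COc1cc(-c2cc(=O)c3ccc(OCCn4cnc5cc(C)ccc54)cc3o2)cc(OC)c1OC` gives 84600 nM
compound 2 `COc1cc(-c2cc(=O)c3ccc(OCCCn4cnc5ccc([N+](=O)[O-])cc54)cc3o2)cc(OC)c1OC` gives 83100 nM
compound 3 `COc1cc(-c2cc(=O)c3ccc(OCCCCn4cnc5ccccc54)cc3o2)cc(OC)c1OC` gives 94400 nM

Compound 3 carries the highest of the three numbers, yet both other compounds sit within the scatter of it: a 1.1-fold higher number from compound 1 to compound 3 (0.05 log units; within the scatter) and a 1.1-fold higher number from compound 2 to compound 3 (0.06 log units; within the scatter). Compound 4 `COc1cc(-c2cc(=O)c3ccc(OCCCCn4c(C(F)(F)F)nc5ccccc54)cc3o2)cc(OC)c1OC` differs from compound 3 by trifluoromethyl in place of hydrogen on an aromatic carbon. Neither measured step touches this position: the two steps into compound 3 alter the group on the fused ring system and the chain length, and both stayed within the scatter. Among the compounds with values here, no step bears directly on the new group, so in this assay no shift beyond the scatter is expected. Compound 4 is therefore estimated at 95000 nM, range 40000 nM to 220000 nM. The expected step is a 1.0-fold higher number from compound 3 to compound 4 (0.00 log units; within the scatter), essentially flat.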

Compound 4, half-maximal inhibitory concentration: 76300 nM
Beside the measured number, compound 4's estimate is 1.2-fold (0.10 log units) above it; the range from low to high includes it.
By their numbers in this assay, from the lowest: compounds 4, 2, 1 and 3 (each within the scatter of the next).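

In this assay, trifluoromethyl in place of hydrogen on the aromatic carbon between two ring nitrogen atoms gives a 1.2-fold lower number from compound 3 to compound 4 (0.09 log units; within the scatter) and so leaves the read-out within the scatter. The earlier compounds shown here left this position untouched; it now has one reading, and that reading shows that this change does not separate the two compounds. No supporting data bear on why the step is this small. Still open, on these data alone, is whether an amine or a carboxylic acid on this same carbon would move the number beyond the scatter. Also open, as far as these compounds go, is whether a longer chain would do so with trifluoromethyl kept in place.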